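Trifluoromethoxy in place of methoxy on a shared core

A few compounds are considered here, and "the series" means these few. Any claim that something is new, unique, unknown or untested is made for them only; others in the source may bear on it.

Measured compounds:
compound 1 `C[C@@H](c1ccc(OC(F)(F)F)cc1)N(Cc1ccc(C(C)(C)C)cc1)Cc1cc2cc(C(F)(F)F)ccc2[nH]c1=O`: > 10000 nM
compound 2 `COc1ccc([C@H](C)N(Cc2ccc(C(C)(C)C)cc2)Cc2cc3cc(C4CC4)ccc3[nH]c2=O)cc1`: > 10000 nM

Compound 1 and compound 2 share a core and were both tested in a toxicity assay on MDCK cells (Canis lupus familiaris) for cytotoxicity, read by crystal violet staining, with a stated time of 48 h; on this read-out lower numbers stand for higher toxicity in this test and higher numbers for lower toxicity in this test. For compound 1 the value > 10000 nM is a limit of this assay, not a number. For compound 2 the value > 10000 nM is likewise a limit. Compound 2 therefore stands at the limit of > 10000 nM in this assay, at which 2 of the 2 values shown sit. Compound 3 `C[C@@H](c1ccc(OC(F)(F)F)cc1)N(Cc1ccc(C(C)(C)C)cc1)Cc1cc2cc(C3CC3)ccc2[nH]c1=O` has not yet been measured in this assay; it differs from compound 2 by trifluoromethyl in place of methyl on an oxygen on an aromatic ring. Among the measured compounds shown here, no step between measured compounds is available. Compound 1, which already carries the trifluoromethoxy group, gives the limit > 10000 nM in this assay. No step beyond the scatter is expected, and the expected step is a step that the limit leaves unreadable from compound 2 to compound 3. For compound 3 the estimate is 20000 nM, between 8000 nM and 60000 nM.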

Compound 3, half-maximal cytotoxic concentration: > 10000 nM
Compound 3: only a limit was reported; the forecaster's own chance of this, stated with the estimate: 85%; the middle value lies beyond the limit too.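

Compound 3 also gives only a limit, so no step from compound 1 or compound 2 to compound 3 can be read in this assay: the limit of > 10000 nM in this assay, at which 3 of the 3 values shown sit.

The compounds shown leave open where the actual half-maximal cytotoxic concentrations of these three compounds lie, and so whether either change shifts them.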